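An Amino-Linked Pyridine in Place of an Ether

The source may report more compounds than this note shows. Statements on the series, on what has been measured and on what is new or still open speak of the compounds shown alone.

Of the compounds shown here, two from this series have been measured in a functional assay on HEK293 cells for positive allosteric modulation of metabotropic glutamate receptor 5 (Homo sapiens), read by FLIPR and calcium flux; a higher number here means that more compound is needed for the effect, a lower number that less compound is needed. Compound 1 `O=C(COCc1ccccc1)N1CCN(c2ccc(Cl)cc2)CC1` carries a benzyloxy-substituted acetamide on the piperazine, and in this assay compound 1 gives 350 nM. Compound 2 `O=C(COCc1ccccn1)N1CCN(c2ccc(Cl)cc2Cl)CC1` bears a second chlorine on the aryl ring and a (pyridin-2-yl)methoxy chain, and in this assay compound 2 gives 310 nM. Of the two numbers, compound 2 holds one that is indistinguishable from compound 1 within the usual scatter, so the two measured compounds show the same order of potency.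

Compound 3 `O=C(CNCc1ccncc1)N1CCN(c2ccc(Cl)cc2Cl)CC1` is built from compound 2 by a single alteration: ((pyridin-4-yl)methyl)amino in place of (pyridin-2-yl)methoxy on a saturated chain carbon bound to a carbonyl carbon. The ether oxygen thus gives way to a secondary amine, and the nitrogen of the pyridine moves to a different ring position. Within the data shown here, no measured pair in this set isolates such a change, so there is no step to lean on; both measured compounds sit close together, which suggests the scaffold tolerates variation in this chain.

The step from compound 2 to compound 3 is expected to be modest, a 1.6-fold higher number from compound 2 to compound 3 (0.21 log units; within the scatter), most likely a small loss or no change beyond the scatter. Compound 3 is therefore estimated at 500 nM, with a plausible range from 150 nM to 1800 nM.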

Compound 3, half-maximal effective concentration: 8500 nM
Compound 3: middle estimate off by 17-fold (1.23 log units), on the low side; the measured number lies above the stated range.
By their numbers in this assay, from the lowest: compounds 2 and 1 (each within the scatter of the next); then compound 3.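

In this assay, the chain on a saturated chain carbon bound to a carbonyl carbon turns out to be far less forgiving than the two earlier, closely matched numbers suggested: ((pyridin-4-yl)methyl)amino in place of (pyridin-2-yl)methoxy gives a 27-fold higher number from compound 2 to compound 3 (1.44 log units; beyond the scatter) and so a large loss. The exchange keeps the count of heavy atoms and the single six-membered aromatic ring with one hetero atom, and it brings in one hydrogen-bond donor where there was none, so a swap that leaves the size of the group unchanged is enough to produce a step of this size. Nothing available bears on why the number rises so steeply.

The linking atom and the ring position of the pyridine nitrogen change together in this step, so the compounds shown leave open which of the two carries the loss, and a ((pyridin-2-yl)methyl)amino chain or a (pyridin-4-yl)methoxy chain would separate them. Also open, on these data alone, is how a tertiary methylamine or an amide at the same linking position would read in this assay.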